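Fluoro for Bromo: From Compound 2 to Compound 3

This account rests on a few compounds, and the source may have more. Where it says the series, first, only, none or still open, it means among the compounds named here.

Within the data shown here, compound 2 `CC(c1ccc(-c2ccccc2)c(F)c1)c1nnc2n1N=C(c1ccc(Br)cc1)CS2` gives 5000 nM in a functional assay on Huh-7 cells (Homo sapiens) for inhibition, read by sulforhodamine B assay, with a stated time of 72 h; a higher number here means a weaker inhibitor, a lower number a stronger inhibitor; the only other measured compound, compound 1 `COc1ccc(C2=Nn3c(nnc3C(C)c3ccc(-c4ccccc4)c(F)c3)SC2)cc1`, gives 4300 nM, and the two numbers lie within the scatter of each other, so neither can be set apart. Among the measured compounds shown here, the single measured step is a 1.2-fold higher number from compound 1 to compound 2 (0.07 log units; within the scatter). That step alters the same aromatic carbon as the new change. Compound 3 `CC(c1ccc(-c2ccccc2)c(F)c1)c1nnc2n1N=C(c1ccc(F)cc1)CS2` differs from compound 2 by fluoro in place of bromo on an aromatic carbon. For the measured compounds named here, with one step within the scatter as the only guide, no shift beyond the scatter is expected: no change at the digits printed from compound 2 to compound 3 (within the scatter). Compound 3 is therefore estimated at 5000 nM, within 2200 nM to 11000 nM.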

Compound 3, half-maximal inhibitory concentration: 4900 nM
Estimate against measurement, compound 3: 1.0-fold (0.01 log units) above; low and high end bracket the measured number.
By their numbers in this assay, from the lowest: compounds 1, 3 and 2 (each within the scatter of the next).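

In this assay, the fluoro group now joins the bromo and methoxy groups on this aromatic carbon: a 1.0-fold lower number from compound 2 to compound 3 (0.01 log units; within the scatter) and a 1.1-fold higher number from compound 1 to compound 3 (0.06 log units; within the scatter) are both within the scatter. All three groups therefore leave the number unresolved, so this swap, like the earlier one, separates nothing at this position. No evidence on why these numbers coincide is available. The compounds shown leave open whether an amine or a carboxylic acid on this carbon would give a number beyond the scatter. They also leave open whether the hydrogen-bearing, unsubstituted phenyl would do so.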